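From iodo to chloro: a single atom changed on compound 1

A few compounds are considered here, and "the series" means these few. Any claim that something is new, unique, unknown or untested is made for them only; others in the source may bear on it.

In a functional assay on T98G cells (Homo sapiens) for cytotoxicity, read by MTT assay, with a stated time of 48 h (on this read-out higher numbers stand for weaker inhibition and lower numbers for stronger inhibition), compound 1 `C/C(=N\NC(=S)Nc1ccccc1I)c1ccccn1` gives 8.09 nM and sits level with compound 3 `CC(=NNC(=S)Nc1ccccc1)c1ccccn1` at 6.8 nM. These two values lie within the usual scatter of each other. Compound 2 `CC(=NNC(=S)Nc1cccc([N+](=O)[O-])c1)c1ccccn1` stands well apart at 140 nM as the highest number of the three.

The move to compound 4 `C/C(=N\NC(=S)Nc1ccccc1Cl)c1ccccn1` is a small one: chloro in place of iodo on an aromatic carbon means chloro in place of iodo on an aromatic carbon, ortho to a large group. One measured step is available, a 21-fold lower number from compound 2 to compound 3 (1.31 log units; beyond the scatter) for hydrogen in place of nitro on an aromatic carbon. It is large, yet it concerns nitro rather than iodo or chloro, so it offers little guidance here.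

A closer hint comes from two values: compound 1 with its iodo gives 8.09 nM and compound 3 without iodo gives 6.8 nM on the same test, and these two numbers cannot be told apart. On that basis, no step beyond the scatter is expected. The estimated move is a 1.1-fold higher number from compound 1 to compound 4 (0.05 log units; within the scatter) and it is expected to stay within the scatter of this assay for this pair. Compound 4 is expected at 9 nM with an estimated range from 3 nM to 30 nM on this evidence.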

Compound 4, half-maximal inhibitory concentration: 1.1 nM
Compound 4: middle estimate off by 8.2-fold (0.91 log units), on the high side; measured number below the stated range.
By their numbers in this assay, from the lowest: compound 4; then compounds 3 and 1 (each within the scatter of the next); then compound 2.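

In this assay, the step of a 7.4-fold lower number from compound 1 to compound 4 (0.87 log units; beyond the scatter) shows that this place on the aromatic ring does respond to which halogen it carries. One heavy atom replaces another, with no change in the counted hydrogen-bond donors, hydrogen-bond acceptors or net charge, and the number still moves beyond the scatter. The earlier compounds shown here could not show this, since compound 1 and compound 3 lie within the scatter of each other, which made it look as if iodo at this place changed nothing compared with hydrogen; with compound 4 at 1.1 nM against compound 3 at 6.8 nM on the same test, chloro does not simply read like the other two.

No measurement at hand accounts for the gap between chloro and iodo. The compounds shown also leave open how fluoro or bromo would read at this same place, and whether a methyl, a methoxy or an amine there would follow chloro or iodo.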